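The source may hold more compounds than are shown below. What is called first, only, known or untested is meant among the compounds shown, and "the series" means these compounds.

The series rests on one shared core, carried by compound 1 `O=C(Nc1cccc(-n2cc(-c3ccncc3)c(-c3ccc(Cl)c(O)c3)n2)c1)Nc1cccc(C(F)(F)F)c1`, compound 2 `O=C(Nc1cccc(-n2cc(-c3ccncc3)c(-c3ccc(Cl)c(O)c3)n2)c1)Nc1ccc(Cl)c(Cl)c1` and compound 3 `COc1cc(-c2nn(-c3cccc(NC(=O)Nc4ccc(Cl)c(C(F)(F)F)c4)c3)cc2-c2ccncc2)ccc1Cl`, and varies in the aryl on the amide-type nitrogen and in the oxygen substituent on the chloro-bearing aryl. In a functional assay on IGROV-1 cells (Homo sapiens) for inhibition, read by sulforhodamine B assay, with a stated time of 48 h (a higher number here means that more compound is tolerated, a lower number that less compound is tolerated), compound 1 gives > 32500 nM, which is a limit of the assay and not a number. Compound 2 likewise gives > 32500 nM in this assay, again a limit. Compound 3 stands at > 32500 nM in this assay, also a limit. Hence the step that the two limits leave unreadable from compound 1 to compound 2 has no readable size. All three measured values sit at the limit of > 32500 nM in this assay, at which 3 of the 3 values shown sit.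

Compound 4 `O=C(Nc1cccc(-n2cc(-c3ccncc3)c(-c3ccc(Cl)c(O)c3)n2)c1)Nc1ccc(Cl)c(C(F)(F)F)c1` differs from compound 3 by hydrogen in place of methyl on an oxygen on an aromatic ring, that is methoxy to hydroxy, 4-chloro-3-methoxyphenyl to 4-chloro-3-hydroxyphenyl. Compound 1 and compound 2 already carry this hydroxy group on the same aryl, and neither reaches a readable number in this assay. Among the measured compounds shown here, no measured step bears directly on this change, and no step in the set has a readable size. Compound 4 is therefore expected to remain at the limit, with a step that the limit leaves unreadable from compound 3 to compound 4 that is expected to be none beyond the scatter. The estimate for compound 4 in this assay is 45000 nM, between 20000 nM and 150000 nM.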

Compound 4, concentration lethal to 50% of the cells: > 32500 nM
Compound 4 gave a limit, no number; the forecaster's own chance of this, stated with the estimate: 85%; the middle value lies beyond the limit too.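

In this assay compound 4 gives > 32500 nM, a limit of the assay and not a number, so none of its steps from compound 1, compound 2 or compound 3 can be read. The compounds shown leave open whether any of these changes alters the lethal concentration at all, as every value sits at one limit: the limit of > 32500 nM in this assay, at which 4 of the 4 values shown sit.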